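The compounds below may be only part of what the source reports. "The series", "measured", "known", "first", "only" and "open" are said of these compounds alone.

Compound 1 `CN(C)c1ccc(C2CC(c3ccc(-n4cncn4)cc3)=NN2S(C)(=O)=O)cc1` carries a methylsulfonyl group on the ring nitrogen of the shared core and a 1H-1,2,4-triazol-1-yl group on one of the aryl rings. In a functional assay on NCI-H1975 cells (Homo sapiens) for inhibition, read by sulforhodamine B assay, tested at 10 uM (a lower number here means less inhibition, a higher number more inhibition at the concentration tested (going by the name of the read-out)), compound 1 gives -3.1%. Compound 2 `Cc1ccc(S(=O)(=O)N2N=C(c3ccc(-n4cncn4)cc3)CC2c2ccc(N(C)C)cc2)cc1` differs from compound 1 at one place only: 4-methylphenyl in place of methyl on a sulfonyl sulfur. In this assay compound 2 gives 20%, which is a step of a number 23.1 percentage points higher from compound 1 to compound 2 (beyond the scatter). Compound 3 `CN(C)c1ccc(C2CC(c3ccc(-n4ccnc4)cc3)=NN2S(C)(=O)=O)cc1` keeps the methylsulfonyl group of compound 1 and differs in the core: 1H-imidazol-1-yl in place of 1H-1,2,4-triazol-1-yl on an aromatic carbon. In this assay compound 3 gives -3.8%. The step of a number 0.7 percentage points lower from compound 1 to compound 3 (within the scatter), so compound 1 and compound 3 cannot be told apart here, while compound 2 stands beyond both of them.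

Compound 4 `Cc1ccc(S(=O)(=O)N2N=C(c3ccc(-n4ccnc4)cc3)CC2c2ccc(N(C)C)cc2)cc1`, not yet measured, is to compound 3 what compound 2 is to compound 1: 4-methylphenyl in place of methyl on a sulfonyl sulfur. The place of this change reads the same word for word in both pairs, so it is the same change, made here on the core of compound 3 rather than on the core of compound 1. Among the four compounds it occurs twice and has been measured once.

Because the core difference left the number unchanged within the scatter a number 0.7 percentage points lower from compound 1 to compound 3 (within the scatter), the step from compound 3 to compound 4 is expected to be a number 23.8 percentage points higher from compound 3 to compound 4 (beyond the scatter), of similar size to the step seen from compound 1 to compound 2. This expectation rests on that single measured pair alone. Compound 4 is therefore expected to give about 20% in this assay, with a likely range from 5% to 35%.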

Compound 4, a percentage reported as inhibition, at one concentration (the size of the read-out at that concentration, not a potency): 50.5%
Compound 4: the middle estimate sits 30.5 percentage points below what was measured; the whole stated range lies below it.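

In this assay, 4-methylphenyl in place of methyl on the sulfonyl sulfur raises the number on both cores, but the size does not carry over from one core to the other; on the core of compound 3 the result is a number 54.3 percentage points higher from compound 3 to compound 4 (beyond the scatter), and the two steps differ: the same change on two cores in this assay, a number 23.1 percentage points higher (beyond the scatter) from compound 1 to compound 2 and a number 54.3 percentage points higher (beyond the scatter) from compound 3 to compound 4, 31.2 percentage points apart, beyond the scatter of two such steps

The same dependence appears from the other side, since 1H-imidazol-1-yl in place of 1H-1,2,4-triazol-1-yl makes no readable difference with methylsulfonyl but, with (4-methylphenyl)sulfonyl present, gives a number 30.5 percentage points higher from compound 2 to compound 4 (beyond the scatter): the same change on two cores in this assay, a number 0.7 percentage points lower (within the scatter) from compound 1 to compound 3 and a number 30.5 percentage points higher (beyond the scatter) from compound 2 to compound 4, 31.2 percentage points apart, beyond the scatter of two such steps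

The two changes therefore do not add independently in these four compounds, although this set of four, read at one concentration, gives neither a potency nor a reason for the interaction, and it does not show that the pattern extends to other compounds in the series.

Still open, from the compounds shown here alone, is whether the larger effect on the imidazole-bearing core belongs to 4-methylphenyl specifically or extends to other groups on the sulfonyl sulfur, such as phenyl, 4-methoxyphenyl or a longer chain like n-butyl. Going by these compounds, it is also open whether another group in the place of the two azoles, such as a carboxylic acid or an amine, would pair with (4-methylphenyl)sulfonyl in the same way.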